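Chloro to bromo: what to expect for compound 4

The source may report more compounds than this note shows. Statements on the series, on what has been measured and on what is new or still open speak of the compounds shown alone.

Measured so far in an ADME assay on cells (Hepatocyte, Mus musculus) for cytotoxicity, read by MTT assay, with a stated time of 24 h; on this read-out higher numbers stand for lower toxicity in this test and lower numbers for higher toxicity in this test:
- compound 1 `Cc1ccc(-c2nn(-c3ccccc3)cc2-c2nc3ccccc3n2S(=O)(=O)c2ccc(C)cc2)cc1`: 102000 nM
- compound 2 `Cc1ccc(-c2nn(-c3ccccc3)cc2-c2nc3ccccc3n2S(=O)(=O)c2cc(C)ccc2C)cc1`: 231000 nM
- compound 3 `Cc1ccc(-c2nn(-c3ccccc3)cc2-c2nc3ccccc3n2S(=O)(=O)c2ccc(Cl)cc2)cc1`: 216000 nM

Compound 3 shares the upper end of this small set with compound 2, since the two differ only within the usual scatter: a 1.1-fold lower number from compound 2 to compound 3 (0.03 log units; within the scatter). Both stand above compound 1, which gives the lowest number and so the highest toxicity in this test.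

Compound 4 `Cc1ccc(-c2nn(-c3ccccc3)cc2-c2nc3ccccc3n2S(=O)(=O)c2ccc(Br)cc2)cc1` has not yet been measured. It has bromo in place of chloro on an aromatic carbon, para to a large group: bromo in place of chloro on an aromatic carbon.

Among the measured compounds shown here, no measured compound carries bromo, so no step shows this exact change. The closest evidence is the change from methyl to chloro on the same carbon, a 2.1-fold higher number from compound 1 to compound 3 (0.33 log units; beyond the scatter), a modest step. Replacing the whole sulfonyl-bound group gave a 2.3-fold higher number from compound 1 to compound 2 (0.36 log units; beyond the scatter), also modest. Compound 3 and compound 2 nevertheless reach similar numbers despite different groups. A swap of one halogen for another is therefore expected to shift this assay little, if at all.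

The expected change is a 1.0-fold higher number from compound 3 to compound 4 (0.01 log units; within the scatter), with no step beyond the scatter foreseen. For compound 4 the estimated value is 220000 nM, with an expected range of 130000 nM to 370000 nM.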

Compound 4, half-maximal cytotoxic concentration: > 300000 nM
Compound 4 ended at the assay's limit (the forecaster's own chance of this, stated with the estimate: 5%); middle value at least 1.3-fold (0.13 log units) from the limit.
By their numbers in this assay, from the lowest: compound 1; then compounds 3 and 2 (each within the scatter of the next). At a limit, above all of these: compound 4.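

In this assay compound 4 gives > 300000 nM, which is a limit of the assay and not a number. Bromo on this carbon, para to a large group, gives an at least 2.9-fold higher number from compound 1 to compound 4 (0.46 log units; beyond the scatter), so a second halogen, after the chloro of compound 3, also stands clear of the methyl group of compound 1 and does not bring back its higher toxicity in this test. Against the other two compounds the results are an at least 1.3-fold higher number from compound 3 to compound 4 (0.14 log units; that floor lies within the scatter) and an at least 1.2-fold higher number from compound 2 to compound 4 (0.11 log units; that floor lies within the scatter), and since both floors lie within the scatter, they neither establish a real gain from chloro to bromo nor rule one out.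

The compounds shown leave open whether this pattern extends to fluoro or iodo on the same carbon, or to quite different groups there, such as an amine or a carboxylic acid. How far compound 4 truly lies from compound 3 also stays open, and the result for compound 4 is the one value in the set that sits at the limit: the limit of > 300000 nM in this assay, at which 1 of the 4 values shown sits.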